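The source may hold more compounds than are shown below. What is called first, only, known or untested is meant among the compounds shown, and "the series" means these compounds.

Measured compounds in a functional assay on CHO-K1 cells for antagonist activity at adenosine receptor A2b (Homo sapiens), read by FLIPR and calcium flux; a lower number here means a stronger inhibitor, a higher number a weaker inhibitor:

- compound 1 `O=C(c1nccs1)c1nc(NCc2cccnc2)nc2ccsc12`, compound 1 gives 176 nM
- compound 2 `O=C(c1ccccc1)c1nc(NCc2cccnc2)nc2ccsc12`, compound 2 gives 511 nM
- compound 3 `Cc1ccc(C(=O)c2nc(NCc3cccnc3)nc3ccsc23)cc1`, compound 3 gives 215 nM

Compound 3 stands second highest of the three numbers in this assay; its nearest neighbour is compound 1, within the scatter, while compound 2 sits a 2.4-fold lower number from compound 2 to compound 3 (0.38 log units; beyond the scatter) away, beyond the scatter.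

Compound 4 `O=C(c1ccncc1)c1nc(NCc2cccnc2)nc2ccsc12` differs from compound 3 by pyridin-4-yl in place of 4-methylphenyl on a carbonyl carbon. Among the compounds with values here, two measured steps bear on this. The exchange of a heteroaryl ring for a plain phenyl gave a 2.9-fold higher number from compound 1 to compound 2 (0.46 log units; beyond the scatter), and removing a methyl from the phenyl corresponds to reversing a 2.4-fold lower number from compound 2 to compound 3 (0.38 log units; beyond the scatter). Compound 4 keeps a heteroaryl ring on the carbonyl carbon, as compound 1 does, but lacks the methyl that separates compound 3 from compound 2. The two effects pull in opposite directions, so the expected step in this assay is small to modest, most likely toward a higher number.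

Compound 4 is therefore estimated at 320 nM in this assay, with a range of 120 nM to 900 nM, amounting to an expected step of a 1.5-fold higher number from compound 3 to compound 4 (0.17 log units; within the scatter).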

Compound 4, half-maximal inhibitory concentration: 869 nM
Beside the measured number, compound 4's estimate is 2.7-fold (0.43 log units) below it, within the range that was stated.
By their numbers in this assay, from the lowest: compounds 1 and 3 (each within the scatter of the next); then compounds 2 and 4 (each within the scatter of the next).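

In this assay, a heteroaryl ring on the carbonyl carbon does not in itself go with a low number: pyridin-4-yl in place of 1,3-thiazol-2-yl gives a 4.9-fold higher number from compound 1 to compound 4 (0.69 log units; beyond the scatter), so the two heteroaryl rings are not interchangeable here. Pyridin-4-yl cannot be told apart from plain phenyl, with a 1.7-fold higher number from compound 2 to compound 4 (0.23 log units; within the scatter), while against 4-methylphenyl it gives a 4.0-fold higher number from compound 3 to compound 4 (0.61 log units; beyond the scatter), so in this small set compounds 2 and 4 form the weaker pair and compounds 1 and 3 the stronger. No measurement is available that would explain these differences.

Still open, going by these compounds, is whether a methyl on the pyridin-4-yl ring would bring the same step as it does on phenyl. On these data alone, the readings of pyridin-3-yl, 4-methoxyphenyl or a saturated cyclohexyl group on the carbonyl carbon also remain unknown.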